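The compounds below may be only part of what the source reports. "The series", "measured", "known", "first", "only" and "open" are said of these compounds alone.

Working notes on the series. In a functional assay on COLO 205 cells (Homo sapiens) for inhibition, read by sulforhodamine B assay, with a stated time of 48 h, tested at 50 uM (on this read-out higher numbers stand for more inhibition of growth at the one concentration tested and lower numbers for less inhibition of growth), compound 3 `COc1cc(/C=C/C(=O)/C=C/c2cc(OC)c(OC)c(OC)c2)ccc1OCc1cn(CCOc2cc(=O)oc3ccccc23)nn1` gives 86%, level within the scatter with compound 1 `COc1cc(/C=C/C(=O)/C=C/c2cccc3ccccc23)ccc1OCc1cn(CCOc2cc(=O)oc3ccccc23)nn1` at 85%. Compound 2 `COc1cc(/C=C/C(=O)/C=C/c2cccs2)ccc1OCc1cn(CCCCCOc2cc(=O)oc3ccccc23)nn1` differs from compound 3 in more than one place. Compound 2 gives 30%, well beyond the scatter from the other two values. It therefore offers no single-change comparison.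

The next compound is compound 4 `COc1ccccc1/C=C/C(=O)/C=C/c1ccc(OCc2cn(CCOc3cc(=O)oc4ccccc34)nn2)c(OC)c1`, which has 2-methoxyphenyl in place of 3,4,5-trimethoxyphenyl on a double-bonded chain carbon bound to a double-bonded chain carbon.

Going by the values given here, only one measured step changes this same place: a number 1 percentage points higher from compound 1 to compound 3 (within the scatter). That replacement of naphthalen-1-yl by 3,4,5-trimethoxyphenyl left this assay within the scatter, so no shift beyond the scatter is expected here, though a single step is thin evidence. The expected change is a number 4 percentage points lower from compound 3 to compound 4 (within the scatter), in a slightly lower direction if it shows at all. For compound 4 the estimated value is 82%, with an expected range of 66% to 93%.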

Compound 4, percent growth inhibition at one concentration: 67%
Beside the measured number, compound 4's estimate is 15 percentage points above it, within the range that was stated.
By their numbers in this assay, from the lowest: compound 2; then compound 4; then compounds 1 and 3 (each within the scatter of the next).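

In this assay the place on a double-bonded chain carbon bound to a double-bonded chain carbon now proves sensitive to the group it carries: 2-methoxyphenyl gives a number 19 percentage points lower from compound 3 to compound 4 (beyond the scatter) in place of 3,4,5-trimethoxyphenyl and a number 18 percentage points lower from compound 1 to compound 4 (beyond the scatter) in place of naphthalen-1-yl on the same core. The earlier step at this place stayed within the scatter, so the level values of compound 1 and compound 3 do not mean that any group here is tolerated. Nothing at hand gives a reason for the lower value of compound 4.

Going by these compounds, it stays open whether that value goes with the number of methoxy groups on the phenyl ring or with where they stand. A 3,4-dimethoxyphenyl, a 4-methoxyphenyl or an unsubstituted phenyl at this place would help separate the two.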